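This account rests on a few compounds, and the source may have more. Where it says the series, first, only, none or still open, it means among the compounds named here.

Compound 1 `Nc1nc2cc(Cl)c(Cl)cc2n1COC(CO)CO` carries an amino group on its core. In a functional assay on KB cells (Homo sapiens) for inhibition (a lower number here means a stronger inhibitor, a higher number a weaker inhibitor), compound 1 gives > 100000 nM, which is a limit of the assay rather than a measured number. Compound 2 `CNc1nc2cc(Cl)c(Cl)cc2n1COC(CO)CO` differs from it by methyl in place of hydrogen on a nitrogen on an aromatic ring. In this assay compound 2 gives > 100000 nM, again a limit and not a number. The step measured between these two therefore reads a step that the two limits leave unreadable from compound 1 to compound 2; because both sit at the limit of > 100000 nM in this assay, at which 3 of the 3 values shown sit, the size of this step cannot be read.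

Compound 3 `CNc1nc2c(Cl)c(Cl)ccc2n1COC(CO)CO` has a different core from compound 1; how the two cores differ is not broken down here. In this assay compound 3 gives > 100000 nM, once more a limit of the assay.

Compound 4 `CN(C)c1nc2c(Cl)c(Cl)ccc2n1COC(CO)CO` is still to be measured. It differs from compound 3 by methyl in place of hydrogen on a nitrogen on an aromatic ring. Within the data shown here, this is the same kind of change as the one between compound 1 and compound 2, not the same change: around the place in compound 4 the nitrogen's other neighbours are an aromatic carbon and a saturated chain carbon, whereas in compound 2 the only other neighbour is an aromatic carbon. Because every value shown sits at the limit of > 100000 nM in this assay, at which 3 of the 3 values shown sit, nothing about the size of such a step can be read, and the expectation for compound 4 rests only on three limits. The step from compound 3 to compound 4 is expected to be a step that the limit leaves unreadable from compound 3 to compound 4, with little confidence in its direction. Compound 4 is therefore expected to give about 300000 nM, most likely again reported only as a limit.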

Compound 4, half-maximal inhibitory concentration: > 100000 nM
Compound 4 was reported as a limit; the forecaster's own chance of this, stated with the estimate: 85%; the middle value does not contradict the limit.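

Among these compounds, no new step can be read: the step between compound 3 and compound 4 has no readable size, just as the one between compound 1 and compound 2 has none, since these values are limits of the assay and not numbers: the limit of > 100000 nM in this assay, at which 4 of the 4 values shown sit.

In this assay the compounds shown leave open whether methyl in place of hydrogen on the nitrogen, or the difference between the two cores, changes inhibition at all.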